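Chloro added to the urea aryl of compound 1

The source may report more compounds than this note shows. Statements on the series, on what has been measured and on what is new or still open speak of the compounds shown alone.

Measured so far:
compound 1 `O=C(Nc1cccc(-n2cc(-c3ccncc3)c(-c3ccc(Cl)c(O)c3)n2)c1)Nc1cccc(C(F)(F)F)c1` — 23800 nM
compound 2 `COc1cc(-c2nn(-c3cccc(NC(=O)Nc4cccc(C(F)(F)F)c4)c3)cc2-c2ccncc2)ccc1Cl` — 1750 nM

Compound 1 stands at the highest of the two numbers in a functional assay on COLO 205 cells (Homo sapiens) for inhibition, read by sulforhodamine B assay, with a stated time of 48 h; a lower number here means a stronger inhibitor of growth, a higher number a weaker inhibitor of growth; its nearest neighbour is compound 2, reached by a 14-fold lower number from compound 1 to compound 2 (1.13 log units; beyond the scatter), a change of methyl in place of hydrogen on an oxygen on an aromatic ring, on the side of the shared core away from the urea.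

Compound 3 `O=C(Nc1cccc(-n2cc(-c3ccncc3)c(-c3ccc(Cl)c(O)c3)n2)c1)Nc1ccc(Cl)c(C(F)(F)F)c1` differs from compound 1 by chloro in place of hydrogen on an aromatic carbon. Going by the values given here, the one measured step, from compound 1 to compound 2, concerns a different part of the molecule and says nothing about substitution on the ring that carries the trifluoromethyl group. Among the compounds with values here, no measured pair bears directly on the change to compound 3, so the expected step in this assay cannot rest on an analogue; a step within the scatter, in either direction, is the plain expectation, the estimate being a 1.6-fold lower number from compound 1 to compound 3 (0.20 log units; within the scatter) with a wide range.

Compound 3 is therefore expected to give about 15000 nM in this assay, estimated between 5000 nM and 50000 nM.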

Compound 3, concentration for total growth inhibition: 6750 nM
Estimate against measurement, compound 3: 2.2-fold (0.35 log units) above; the range from low to high includes it.
By their numbers in this assay, from the lowest: compound 2; then compound 3; then compound 1.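

In this assay, chloro in place of hydrogen on the aromatic carbon ortho to the trifluoromethyl group and para to a large group gives a 3.5-fold lower number from compound 1 to compound 3 (0.55 log units; beyond the scatter), so the ring carrying the trifluoromethyl group, which the earlier pair did not touch, also responds to substitution. Set beside a 14-fold lower number from compound 1 to compound 2 (1.13 log units; beyond the scatter), this makes two single changes from compound 1 that both lower the number, one on each side of the urea, with the chloro step printed as modest and the methyl step as large. Nothing at hand accounts for the chloro step.

From the compounds shown here alone, whether this carbon favours chloro in particular or tolerates other groups remains open, and a fluoro, a methyl, a methoxy or an amine in the same place would separate those readings. Going by these compounds, it also remains open whether the two steps add up in one molecule, which a compound joining the methyl on the oxygen of compound 2 with the chloro of compound 3 would show.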